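Andrographolide-type lactones: aryl change on the amine nitrogen

The source may report more compounds than this note shows. Statements on the series, on what has been measured and on what is new or still open speak of the compounds shown alone.

Measured so far:
compound 1, `C=C1CC[C@@H]2[C@](C)(CO[Si](C)(C)C(C)(C)C)[C@H](OC(C)=O)CC[C@@]2(C)[C@@H]1C/C=C1/C(=O)OC[C@H]1OC(C)=O` — 3990 nM
compound 2, `C=C1[C@@H](OC(C)=O)C[C@@H]2[C@](C)(COC=O)[C@H](OC(C)=O)CC[C@@]2(C)[C@@H]1C[C@@H](Nc1ccccc1F)C1=CCOC1=O` — 23600 nM
compound 3, `C=C1[C@@H](OC(C)=O)C[C@@H]2[C@](C)(CO[Si](C)(C)C(C)(C)C)[C@H](OC(C)=O)CC[C@@]2(C)[C@@H]1C[C@@H](Nc1ccccc1F)C1=CCOC1=O` — 3190 nM

The numbers come from a functional assay on A549 cells (Homo sapiens) for cytotoxicity, read by sulforhodamine B assay; on this read-out higher numbers stand for weaker inhibition and lower numbers for stronger inhibition. Compound 3 stands at the lowest of the three numbers, but its distance to compound 1 lies within the scatter, so the two cannot be ordered; only compound 2 stands clearly apart. Going by the values given here, the one step between neighbours, a 7.4-fold lower number from compound 2 to compound 3 (0.87 log units; beyond the scatter), concerns the group on the oxygen on a saturated carbon and not the aryl on the amine nitrogen.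

Compound 4, `C=C1[C@@H](OC(C)=O)C[C@@H]2[C@](C)(CO[Si](C)(C)C(C)(C)C)[C@H](OC(C)=O)CC[C@@]2(C)[C@@H]1C[C@@H](Nc1cccc2ccccc12)C1=CCOC1=O`, differs from compound 3 in one place: naphthalen-1-yl in place of 2-fluorophenyl on an amine nitrogen. Among the compounds with values here, no measured pair changes this aryl group, so no step here bears on the change; the shared core and the remaining substituents are kept. The only ground for an expectation is that compound 3 gives 3190 nM and that the change leaves the rest of the molecule untouched. A step of a 1.0-fold higher number from compound 3 to compound 4 (0.00 log units; within the scatter) is therefore expected to stay within the scatter, without a direction that the data can support. For compound 4 the number in this assay is estimated at 3200 nM, within 1000 nM to 10000 nM.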

Compound 4, half-maximal inhibitory concentration: 4970 nM
Compound 4: middle estimate off by 1.6-fold (0.19 log units), on the low side, and the stated range covers the measured number.
By their numbers in this assay, from the lowest: compounds 3, 1 and 4 (each within the scatter of the next); then compound 2.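

Working notes on the amine nitrogen: in this assay, a 1.6-fold higher number from compound 3 to compound 4 (0.19 log units; within the scatter) gives the first reading at this position, and compounds 3 and 4 cannot be ordered. Replacing 2-fluorophenyl with naphthalen-1-yl adds a second six-membered aromatic ring and removes the fluorine, yet the step does not go beyond the scatter, so this pair shows no measurable dependence on which of these two aryl groups is present. The earlier step, a 7.4-fold lower number from compound 2 to compound 3 (0.87 log units; beyond the scatter), concerned only the group on the oxygen on a saturated carbon and said nothing about the aryl group, and no measurement at hand bears on why this aryl change leaves the number within the scatter.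

The compounds shown cover only two carbon-only aromatic groups on the amine nitrogen, so it remains open whether a pyridin-3-yl ring, a cyclohexyl ring or an ethyl chain there would also stay within the scatter of compound 3. Also open, going by these compounds, is whether the same aryl change reads alike when the oxygen on a saturated carbon carries the group found in compound 2, which gives 23600 nM with 2-fluorophenyl.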